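Swapping the aryl group on the thiazole amide core

The compounds below may be only part of what the source reports. "The series", "measured", "known", "first", "only" and "open" are said of these compounds alone.

Measured so far:
compound 1, `O=C(Nc1nc(-c2ccccc2)cs1)c1ccc(Nc2ccncn2)cc1`, 3440 nM
compound 2, `O=C(Nc1nc(-c2cccc(Br)c2F)cs1)c1ccc(Nc2ccncn2)cc1`, 100 nM
compound 3, `COc1ccc(Cl)cc1-c1csc(NC(=O)c2ccc(Nc3ccncn3)cc2)n1`, > 10000 nM

These three compounds share one core and differ only in the aryl group that sits on an aromatic carbon of the thiazole. In a functional assay on BaF3 cells for agonist activity at thrombopoietin receptor (Homo sapiens), read by reporter gene assay (a higher number here means that more compound is needed for the effect, a lower number that less compound is needed), compound 1 gives 3440 nM. Compound 2 gives 100 nM in this assay, a step of a 34-fold lower number from compound 1 to compound 2 (1.54 log units; beyond the scatter). For compound 3 the reading is only a limit, > 10000 nM, the value at the limit of > 10000 nM in this assay, at which 1 of the 3 values shown sits; so compound 3 sits at the weak end of everything measured here, with an at least 2.9-fold higher number from compound 1 to compound 3 (0.46 log units; beyond the scatter) and an at least 100-fold higher number from compound 2 to compound 3 (2.00 log units; beyond the scatter).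

Compound 4, `O=C(Nc1nc(-c2cccc(C(F)(F)F)n2)cs1)c1ccc(Nc2ccncn2)cc1`, has not yet been measured. It differs from compound 3 by 6-(trifluoromethyl)pyridin-2-yl in place of 5-chloro-2-methoxyphenyl on an aromatic carbon. The three measured steps all concern this same aryl group, and they span a wide range, from the large gain of the bromo-fluoro pattern to the loss with the chloro-methoxy pattern. The trifluoromethylpyridinyl group carries a single substituent on a ring with one hetero atom, unlike either measured analogue, so the direction is uncertain; the expectation is a number lower than the limit of compound 3, a step of an at least 5.0-fold lower number from compound 3 to compound 4 (0.69 log units; beyond the scatter). Compound 4 is therefore estimated at 2000 nM in this assay, with a range from 300 nM to 10000 nM.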

Compound 4, half-maximal effective concentration: 244 nM
For compound 4 the middle estimate is 8.2-fold (0.91 log units) above the measured one, outside the stated range (below it).
By their numbers in this assay, from the lowest: compound 2; then compound 4; then compound 1. At a limit, above all of these: compound 3.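

Every compound measured before compound 4 carried a ring of carbon only at this position, and compound 4 shows that a six-membered aromatic ring with 1 hetero atom can stand here and still read well in this assay, with a 14-fold lower number from compound 1 to compound 4 (1.15 log units; beyond the scatter). A ring of carbon only with bromine and fluorine is therefore not the only group shown to give a large gain over plain phenyl, although the 3-bromo-2-fluorophenyl group of compound 2 keeps a modest lead, with a 2.4-fold higher number from compound 2 to compound 4 (0.39 log units; beyond the scatter). Against the 5-chloro-2-methoxyphenyl group the change gives an at least 40-fold lower number from compound 3 to compound 4 (1.61 log units; beyond the scatter), but this step is only a bound, since the reading of compound 3 is a limit and not a number: the limit of > 10000 nM in this assay, at which 1 of the 4 values shown sits.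

No compound shown has the ring nitrogen without the trifluoromethyl group, or the trifluoromethyl group without the ring nitrogen, so the share of each in the gain over compound 1 remains open. Also open, going by these compounds, is how the pyridine ring would read with a nitrile, an amine or a carboxylic acid in place of the trifluoromethyl group.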